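Exchanging 4-fluorophenyl for 2,4-dichlorophenyl in a well-tolerated series

The source may report more compounds than this note shows. Statements on the series, on what has been measured and on what is new or still open speak of the compounds shown alone.

In an ADME assay on J774 cells (Mus musculus) for cytotoxicity, read by resazurin assay, with a stated time of 72 h (a lower number here means that less compound is tolerated, a higher number that more compound is tolerated), compound 1 (`C/C(=N\Nc1nc(C)cs1)c1ccc(Cl)c(Cl)c1`) gives 33700 nM as its half-maximal cytotoxic concentration, and compound 2 (`C/C(=N\Nc1nc(-c2ccncc2)cs1)c1ccc(Cl)c(Cl)c1`) gives 39800 nM on the same read-out. Compound 3 (`C/C(=N\Nc1nc(-c2ccc(F)cc2)cs1)c1ccc(Cl)c(Cl)c1`) has only a limit of > 50000 nM in this assay and no exact number.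

Compound 4 (`C/C(=N\Nc1nc(-c2ccc(Cl)cc2Cl)cs1)c1ccc(Cl)c(Cl)c1`) differs from compound 3 at one place (2,4-dichlorophenyl in place of 4-fluorophenyl on an aromatic carbon): 2,4-dichlorophenyl stands in place of 4-fluorophenyl on an aromatic carbon of the five-membered aromatic ring, next to the ring nitrogen.

Among the measured compounds shown here, the measured changes at this same carbon are the only guide. Putting 4-fluorophenyl in place of methyl gave an at least 1.4-fold higher number from compound 1 to compound 3 (0.17 log units; that floor lies within the scatter) and putting pyridin-4-yl in place of methyl gave a 1.2-fold higher number from compound 1 to compound 2 (0.07 log units; within the scatter) while 4-fluorophenyl in place of pyridin-4-yl gave an at least 1.2-fold higher number from compound 2 to compound 3 (0.09 log units; that floor lies within the scatter) in this assay as well. None of these shows a change beyond the scatter, although the two steps into compound 3 are floors set by a limit. For the measured compounds named here, no measured compound carries 2,4-dichlorophenyl, so some caution remains, but no step beyond the scatter is expected. The step expected is an at least 1.2-fold lower number from compound 3 to compound 4 (0.09 log units; that floor lies within the scatter) which is an estimate and not a measurement. The estimated value for compound 4 is 40000 nM within an expected range of 18000 nM to 60000 nM for a single measurement.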

Compound 4, half-maximal cytotoxic concentration: > 50000 nM
Compound 4: a limit, no number (the forecaster's own chance of this, stated with the estimate: 35%); at least 1.2-fold (0.09 log units) between middle value and limit.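

Compound 4 stands in this assay at a limit, > 50000 nM, and not at a number. With 2,4-dichlorophenyl on this carbon of the five-membered aromatic ring, the comparison with pyridin-4-yl gives an at least 1.2-fold higher number from compound 2 to compound 4 (0.09 log units; that floor lies within the scatter), and the comparison with methyl gives an at least 1.4-fold higher number from compound 1 to compound 4 (0.17 log units; that floor lies within the scatter), so the position now accepts a second halogen-bearing phenyl group without any fall in the number coming into view, although neither floor shows a step beyond the scatter. The exchange of 4-fluorophenyl for 2,4-dichlorophenyl itself cannot be read, because compound 3 and compound 4 stand at the same limit: the limit of > 50000 nM in this assay, at which 2 of the 4 values shown sit.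

Going by these compounds, how far compound 3 and compound 4 each lie past that limit stays open, and with it whether the two chlorine atoms change the tolerated concentration at all, in either direction. Also open, on these data alone, is whether a phenyl ring carrying an amine or a carboxylic acid, or a longer alkyl chain on this same carbon, would keep the number in this range or bring it down.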